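Compound 1 and the Methoxypropyl Swap

The compounds below may be only part of what the source reports. "The series", "measured", "known", "first", "only" and "open" are said of these compounds alone.

Measured in a physicochemical assay for solubility, using the shake flask method, in phosphate buffer, with a stated time of 90 min, at pH 6.8; on this read-out higher numbers stand for higher solubility and lower numbers for lower solubility:
- compound 1 `COc1cc(/C=C/C(=O)/C=C(/C=C/c2ccc(O)c(OC)c2)NCCO)ccc1O`: 8140 nM
- compound 2 `COCCCN1C(/C=C/c2ccc(O)cc2)=CC(=O)CC1c1ccc(O)cc1`: 25800 nM

Of these two compounds, compound 1 holds the lower number, and compound 2 stands above it by more than the usual scatter. The two are not linked by a change in one place, so their values give no measured size for any single structural change.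

The next compound to be tested is compound 3 `COCCCNC(=C\C(=O)/C=C/c1ccc(O)c(OC)c1)/C=C/c1ccc(O)c(OC)c1`. Its difference from compound 1 is methoxymethyl in place of hydroxy on a saturated chain carbon, two bonds along the chain from an amine nitrogen. Read one bond further out, 2-hydroxyethyl gives way to 3-methoxypropyl.

Going by the values given here, no measured pair shows this change alone in this assay. The expectation therefore stays anchored on compound 1 at 8140 nM, leaning only slightly lower. The expected change is a 1.6-fold lower number from compound 1 to compound 3 (0.21 log units; within the scatter), a small downward move that is not expected to clear the scatter. For compound 3 the estimated value is 5000 nM, with an expected range from 1500 nM to 16000 nM.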

Compound 3, solubility: 7700 nM
Compound 3: the middle estimate sits 1.5-fold (0.19 log units) below what was measured; the range from low to high includes it.
By their numbers in this assay, from the lowest: compounds 3 and 1 (each within the scatter of the next); then compound 2.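

In this assay, the exchange of 2-hydroxyethyl for 3-methoxypropyl gives a 1.1-fold lower number from compound 1 to compound 3 (0.02 log units; within the scatter), the first measured size for any single change in this series, which compound 1 and compound 2 could not provide. At this place on the shared core, hydroxy, a hydrogen-bond donor, can therefore give way to methoxymethyl, which is not one, with the two values remaining within the scatter of each other. Nothing available explains why the step is this size, and no supporting measurement bears on it.

Going by these compounds alone, the single step changes the end group and the chain length together, so it leaves open what each contributes alone; 3-hydroxypropyl or 2-methoxyethyl in the same place on the core of compound 1 would separate the two. Also open, going by these compounds, is whether the flat result extends beyond neutral chains of this length, since a 3-(dimethylamino)propyl group, a 3-carboxypropyl group carrying a carboxylic acid, or a longer chain such as 4-methoxybutyl could give a step of a different size in this assay.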